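Chain shortening on the peracetylated thiadiazole glycoside amides

The compounds below may be only part of what the source reports. "The series", "measured", "known", "first", "only" and "open" are said of these compounds alone.

Measured so far:
- compound 1, `CCCCCCCCCCCCCC(=O)Nc1nnc(S[C@@H]2O[C@H](COC(C)=O)[C@H](OC(C)=O)[C@H](OC(C)=O)[C@H]2OC(C)=O)s1`: 61300 nM
- compound 2, `CCCCCCCCCCCC(=O)Nc1nnc(S[C@@H]2O[C@H](CO)[C@H](O)[C@H](O)[C@H]2O)s1`: 8700 nM
- compound 3, `CCCCCCCC/C=C\CCCCCCCCCCCC(=O)Nc1nnc(S[C@@H]2O[C@H](COC(C)=O)[C@H](OC(C)=O)[C@H](OC(C)=O)[C@H]2OC(C)=O)s1`: 58500 nM

In a functional assay on HeLa cells (Homo sapiens) for cytotoxicity, read by MTT assay, with a stated time of 24 h (on this read-out lower numbers stand for stronger inhibition and higher numbers for weaker inhibition), compound 1 gives 61300 nM, the highest of the three numbers. Compound 3 sits at 58500 nM, and the step of a 1.0-fold lower number from compound 1 to compound 3 (0.02 log units; within the scatter) shows that lengthening the chain and adding the unsaturation at the far end changes nothing that can be read. Compound 2, which carries the shorter dodecanoyl chain and lacks all four acetyl groups, gives 8700 nM; it differs from compound 1 in two places at once, so its gap to compound 1 cannot be assigned to either change.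

Compound 4, `CCCCCCCC(=O)Nc1nnc(S[C@@H]2O[C@H](COC(C)=O)[C@H](OC(C)=O)[C@H](OC(C)=O)[C@H]2OC(C)=O)s1`, keeps the peracetylated core of compound 1 and differs from it by hydrogen in place of hexyl on a saturated chain carbon, seven bonds along the chain from a carbonyl carbon. For the measured compounds named here, no measured step covers a shortening of the chain on this core. Going by the values given here, the only step at the chain end, from compound 1 to compound 3, stayed within the scatter, so the expectation is a step no larger than the scatter in this assay, in no particular direction: a 1.0-fold lower number from compound 1 to compound 4 (0.01 log units; within the scatter) is the estimate. Compound 4 is expected at 60000 nM, between 25000 nM and 150000 nM.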

Compound 4, half-maximal inhibitory concentration: 43600 nM
For compound 4 the middle estimate is 1.4-fold (0.14 log units) above the measured one; low and high end bracket the measured number.
By their numbers in this assay, from the lowest: compound 2; then compounds 4, 3 and 1 (each within the scatter of the next).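

In this assay the result gives a 1.4-fold lower number from compound 1 to compound 4 (0.15 log units; within the scatter) as the first read on cutting back the chain of the peracetylated series, with hydrogen in place of hexyl on a saturated chain carbon, seven bonds along the chain from a carbonyl carbon. Set beside a 1.0-fold lower number from compound 1 to compound 3 (0.02 log units; within the scatter) on the same core, it shows that neither this removal of hexyl nor the longer unsaturated chain moves the number beyond the scatter, so compound 1, compound 3 and compound 4 give no readable dependence on chain length; compound 2 stays outside this statement, as it does not carry the acetyl groups. No measurement is available here to explain this flat result.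

For the compounds shown here, still open is whether the four acetyl groups matter on their own, as compound 2 differs from each other compound in more than one place and no pair isolates that change. Also open, from the compounds shown here alone, is whether an amine or a carboxylic acid in place of hexyl at this position, or a much shorter acyl chain on the same core, would give a step beyond the scatter.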